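Removing One Chloro from Compound 2

The source may report more compounds than this note shows. Statements on the series, on what has been measured and on what is new or still open speak of the compounds shown alone.

Compound 1 `COc1cc(Cl)ccc1C(=S)Nc1ccc(Cl)cc1` gives 2930 nM
Compound 2 `COc1cc(Cl)ccc1C(=S)Nc1ccc(Cl)c(Cl)c1` gives 6500 nM
Compound 3 `COc1cc(Cl)ccc1C(=S)Nc1cccc(Cl)c1` awaits measurement

In an ADME assay on HepG2 cells (Homo sapiens) for cytotoxicity, with a stated time of 24 h (on this read-out lower numbers stand for stronger inhibition and higher numbers for weaker inhibition), compound 2 stands highest of the two measured compounds at 6500 nM. Compound 3 differs from it by hydrogen in place of chloro on an aromatic carbon. Among the compounds with values here, the only measured step that bears on this is a 2.2-fold higher number from compound 1 to compound 2 (0.35 log units; beyond the scatter), where a chloro entered on another carbon, so it is a rough guide. A similarly modest move to a lower number is expected in this assay, though it may stay within the scatter. The estimated change is a 1.9-fold lower number from compound 2 to compound 3 (0.27 log units; within the scatter). Compound 3 is expected at 3500 nM, within an estimated range of 1600 nM to 7500 nM.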

Compound 3, half-maximal inhibitory concentration: 11700 nM
Compound 3: the middle estimate sits 3.3-fold (0.52 log units) below what was measured; measured number outside the range, above it.
By their numbers in this assay, from the lowest: compound 1; then compounds 2 and 3 (each within the scatter of the next).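

In this assay, hydrogen in place of the chloro para to a large group gives a 1.8-fold higher number from compound 2 to compound 3 (0.26 log units; within the scatter), so at this position, ortho to a chloro group, the change does not move the number beyond the scatter. With the other chloro kept, this chloro is thus not needed to hold the number at the level of compound 2. No measurement available here explains this result.

The compounds shown leave open whether a methoxy group, an amine or a carboxylic acid at this position would shift the number beyond the scatter.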